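Shortening the sulfanyl chain of compound 3

This account rests on a few compounds, and the source may have more. Where it says the series, first, only, none or still open, it means among the compounds named here.

In an ADME assay on 184B5 cells (Homo sapiens) for cytotoxicity, read by MTT assay, with a stated time of 72 h (on this read-out higher numbers stand for weaker inhibition of growth and lower numbers for stronger inhibition of growth), compound 3, `CCCCCSc1nc(NCc2ccc([Se]C)cc2)c2ccccc2n1`, gives > 100000 nM, which is a limit of the assay and not a number. Compound 1, `CCCCC[Se]c1nc([Se]CCCCC)c2cccnc2n1`, likewise reaches only a limit, > 100000 nM. For compound 2, `C[Se]c1nc([Se]C)c2cccnc2n1`, the entry is "not determined" (no result reported), so no result exists. Among the measured compounds shown here, compound 3 therefore stands on a limit, beside one further limit and one entry without a number, and no step between measured compounds can be read from these data; what the two measured values share is the limit of > 100000 nM in this assay, at which 2 of the 3 values shown sit. Compound 4, `CSc1nc(NCc2ccc([Se]C)cc2)c2ccccc2n1`, differs from compound 3 in one place: hydrogen in place of butyl on a saturated chain carbon bound to a sulfur. With both measured values sitting where the limit of > 100000 nM in this assay, at which 2 of the 3 values shown sit, puts them, the step from compound 3 to compound 4 is expected to be a number no higher from compound 3 to compound 4 (the limit leaves the size open), no shift beyond the scatter in either direction. Compound 4 is thus estimated at 100000 nM, within a range from 30000 nM to 300000 nM, and most probably again reported only as a limit.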

Compound 4, concentration for total growth inhibition: > 100000 nM
Compound 4: only a limit was reported (the forecaster's own chance of this, stated with the estimate: 85%); the middle value lies on the limit itself.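

Among the compounds shown here, compound 3 and compound 4 are both reported only as limits, not numbers, so no step between them can be read in this assay. What the values share is this: the limit of > 100000 nM in this assay, at which 3 of the 4 values shown sit.

The compounds shown leave open how far changing pentylsulfanyl to methylsulfanyl shifts growth inhibition.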